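A few compounds are considered here, and "the series" means these few. Any claim that something is new, unique, unknown or untested is made for them only; others in the source may bear on it.

Measured so far:
- Compound 1 `COc1ccc(N/N=C2\C(=O)N(Cc3cn(O[C@@H]4O[C@H](CC(C)=O)[C@@H](OC(C)=O)[C@H](OC(C)=O)[C@H]4OC(C)=O)nn3)c3ccccc32)cc1` — 95300 nM
- Compound 2 `CC(=O)C[C@H]1O[C@@H](On2cc(CN3C(=O)/C(=N\Nc4ccc(F)cc4)c4ccccc43)nn2)[C@H](OC(C)=O)[C@@H](OC(C)=O)[C@@H]1OC(C)=O` — 68700 nM
- Compound 3 `CC(=O)C[C@H]1O[C@@H](On2cc(CN3C(=O)/C(=N\Nc4cccc(Cl)c4)c4ccccc43)nn2)[C@H](OC(C)=O)[C@@H](OC(C)=O)[C@@H]1OC(C)=O` — 117000 nM

All three numbers come from an ADME assay on Vero cells (Chlorocebus sabaeus) for cytotoxicity, read by fluorescence and resazurin assay, with a stated time of 3 days; a lower number here means that less compound is tolerated, a higher number that more compound is tolerated. Compound 2 gives the lowest of the three, but its separation from the others is small: one of the neighbouring steps is a 1.4-fold lower number from compound 1 to compound 2 (0.14 log units; within the scatter), and the other is a 1.7-fold higher number from compound 2 to compound 3 (0.23 log units; within the scatter), both within the usual scatter. The step from compound 1 to compound 3 is a 1.2-fold higher number from compound 1 to compound 3 (0.09 log units; within the scatter), also within the scatter, so across these three the numbers in this assay are indistinguishable.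

Compound 4 `CC(=O)C[C@H]1O[C@@H](On2cc(CN3C(=O)/C(=N\Nc4ccc(F)cc4)c4ccccc43)nn2)[C@H](OC(C)=O)[C@@H](OC(C)=O)[C@H]1OC(C)=O` has not yet been measured. Compared with compound 2 it shows (the two compounds have the same atoms and bonds and differ only in configuration as drawn: 1 of 6 stereo elements differ; a stereocentre at a saturated ring carbon is drawn R in compound 2 and S in compound 4).

Within the data shown here, none of the measured steps involves a change of configuration; all three concern a swap of the aryl group on the amine nitrogen, and each stayed within the scatter. Among the measured compounds shown here, there is therefore no measured step that bears directly on this change, and nothing in the data indicates a shift beyond the scatter. The expected step in this assay from compound 2 to compound 4 is a 1.0-fold higher number from compound 2 to compound 4 (0.01 log units; within the scatter). The estimated value for compound 4 in this assay is 70000 nM, with an expected range from 35000 nM to 140000 nM.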

Compound 4, half-maximal cytotoxic concentration: 78600 nM
For compound 4 the middle estimate is 1.1-fold (0.05 log units) below the measured one; measured number inside the range.
By their numbers in this assay, from the lowest: compounds 2, 4, 1 and 3 (each within the scatter of the next).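

Among these compounds, until now the measured steps had concerned only the aryl group on the amine nitrogen, so this pair gives the first reading on configuration, at a saturated ring carbon drawn R in compound 2 and S in compound 4, and the comparison rests on that one feature: the fact that compounds 2 and 4 differ only in the configuration as drawn. In this assay the result is a 1.1-fold higher number from compound 2 to compound 4 (0.06 log units; within the scatter), so with the 4-fluorophenyl group in place, the two drawn configurations at this stereocentre cannot be told apart. Among these four compounds, neither the aryl swaps nor this inversion has produced a step beyond the scatter in this assay.

The compounds shown leave open whether the same would hold for inversion at the other stereo elements, or at this stereocentre with the 4-methoxyphenyl or 3-chlorophenyl group in place of 4-fluorophenyl. They also leave open what this assay would read if the acetoxy groups gave way to free hydroxyl groups, or if the aryl group carried an amine or a carboxylic acid.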